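Changing the Group on a Sulfonyl Sulfur

This account rests on a few compounds, and the source may have more. Where it says the series, first, only, none or still open, it means among the compounds named here.

In an ADME assay on microsomes from liver (Homo sapiens) for pharmacokinetics, read by LC-MS, with a stated time of 60 min, tested at 1 uM (a lower number here means slower removal, a higher number faster removal of the compound), compound 1 (`O=C(NCc1ccc(S(=O)(=O)c2ccccc2)cc1)N1Cc2ccncc2C1`) gives 7.5 mL/min/kg and compound 2 (`CC(=O)N1CCC(S(=O)(=O)c2ccc(CNC(=O)N3Cc4ccncc4C3)cc2)CC1`) gives 6 mL/min/kg so these two values lie within the usual scatter of each other. Compound 3 (`O=C(NCc1ccc(S(=O)(=O)N2CCOCC2)cc1)N1Cc2ccncc2C1`) carries morpholin-4-yl in place of 1-acetylpiperidin-4-yl on a sulfonyl sulfur. Among the measured compounds shown here, the only measured change at this sulfur is small (a 1.3-fold lower number from compound 1 to compound 2 (0.10 log units; within the scatter)) and offers no sign of a larger effect. In this assay the expected step (a 1.2-fold higher number from compound 2 to compound 3 (0.07 log units; within the scatter)) therefore stays within the scatter. Compound 3 is estimated at 7 mL/min/kg with an expected range from 4 mL/min/kg to 13 mL/min/kg for its clearance.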

Compound 3, clearance: 9 mL/min/kg
For compound 3 the middle estimate is 1.3-fold (0.11 log units) below the measured one, within the range that was stated.
By their numbers in this assay, from the lowest: compounds 2, 1 and 3 (each within the scatter of the next).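

In this assay, morpholin-4-yl in place of 1-acetylpiperidin-4-yl gives a 1.5-fold higher number from compound 2 to compound 3 (0.18 log units; within the scatter) and morpholin-4-yl in place of phenyl gives a 1.2-fold higher number from compound 1 to compound 3 (0.08 log units; within the scatter) on this sulfonyl sulfur. Among the compounds shown here, three quite different groups at this position therefore now sit within the scatter of one another, where previously only a single pair could be compared. No measurement shown explains this closeness.
Going by these compounds, whether a carboxylic acid or a primary amine on this sulfur would step beyond the scatter remains open. So does whether a small methyl group would.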